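The source may report more compounds than this note shows. Statements on the series, on what has been measured and on what is new or still open speak of the compounds shown alone.

Measured compounds in an assay on isolated protein for agonist activity at Bile acid receptor (Homo sapiens), read by AlphaScreen, with a stated time of 30 min; on this read-out lower numbers stand for an effect already at smaller amounts and higher numbers for an effect only at larger amounts of compound:
compound 2 `Cc1ccccc1-n1nc(C)c2c1NC(=O)[C@H](C)S[C@@H]2c1ccc(-c2ccsc2)cc1` — 1400 nM
compound 3 `COc1cc([C@H]2S[C@@H](C)C(=O)Nc3c2c(C)nn3-c2ccccc2C)ccc1Oc1ccccc1` — 1900 nM
compound 1 `Cc1nn(-c2ccccc2Cl)c2c1C(c1ccc(Oc3ccccc3)cc1)SC(C)C(=O)N2` — 2700 nM

In this assay compound 2 carries the lowest of the three numbers, yet its gaps to compound 3 and to compound 1 both fall within the usual scatter, so the three compounds cannot be ordered on these values; the shared core with varied groups on the pendant ring gives a flat picture so far.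

Compound 4 `Cc1ccccc1-n1nc(C)c2c1NC(=O)[C@H](C)S[C@@H]2c1ccc(Oc2ccc(C(=O)O)cc2)cc1` is the next point. Relative to compound 2 the change is 4-carboxyphenoxy in place of thiophen-3-yl on an aromatic carbon. Within the data shown here, no measured pair shows this or any single change, so there is no step to lean on; the expectation rests only on the narrow spread seen across compound 1, compound 2 and compound 3. A modest step toward lower numbers is expected for compound 4, of a size that may not clear the scatter, as a 1.8-fold lower number from compound 2 to compound 4 (0.24 log units; within the scatter).

Compound 4 is estimated at 800 nM, with a range from 200 nM to 3200 nM.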

Compound 4, half-maximal effective concentration: "not active" (no number reported)
Compound 4: no number reported, so the estimate cannot be set against anything.
By their numbers in this assay, from the lowest: compounds 2, 3 and 1 (each within the scatter of the next).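

In this assay, among these compounds, compound 4 is reported as not active, without a number, so no step from compound 2 can be read. Nothing available bears on this result. The compounds shown leave open how any single change, including 4-carboxyphenoxy in place of thiophen-3-yl, shifts the read-out.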